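Removing a Chloro Group From a Cell Growth Inhibitor

A few compounds are considered here, and "the series" means these few. Any claim that something is new, unique, unknown or untested is made for them only; others in the source may bear on it.

Measured so far in an ADME assay on HepG2 cells (Homo sapiens) for inhibition, read by fluorescence and resazurin assay, with a stated time of 72 h; on this read-out higher numbers stand for weaker inhibition and lower numbers for stronger inhibition:
compound 1, `NS(=O)(=O)c1ccc(Nc2nccc(Nc3ccc4cn[nH]c4c3)n2)cc1`: 22000 nM
compound 2, `NS(=O)(=O)c1cccc(Nc2nccc(Nc3ccc4nc[nH]c4c3)n2)c1`: a limit of the assay, > 25000 nM
compound 3, `NS(=O)(=O)c1ccc(Nc2ncc(Cl)c(Nc3ccc4nc[nH]c4c3)n2)cc1`: 7800 nM

Of the compounds shown here, three built on a shared core have been tested. Compound 1 gives 22000 nM. Compound 2 reaches only a limit of the assay, recorded as > 25000 nM. Compound 3 gives 7800 nM. Of the two numbers that are not limits, compound 3 has the lowest, so it is the stronger inhibitor of the pair, and its gap to compound 1 lies beyond the usual scatter of this measurement.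

Compound 4, `NS(=O)(=O)c1ccc(Nc2nccc(Nc3ccc4nc[nH]c4c3)n2)cc1`, has not yet been measured. It differs from compound 3 in one place: hydrogen in place of chloro on an aromatic carbon. Among the measured compounds shown here, no measured pair differs by this same change alone, so the size of this step cannot be read off from the data; it has to be estimated. The expectation is that compound 4 loses some inhibition, giving a step of a 2.6-fold higher number from compound 3 to compound 4 (0.41 log units; beyond the scatter) in this assay, a change beyond the usual scatter but not a large one. Compound 4 is therefore estimated at 20000 nM, with a likely range from 8000 nM to 50000 nM, and some chance that the assay reports only a limit.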

Compound 4, half-maximal inhibitory concentration: > 25000 nM
Compound 4: a limit, no number (the forecaster's own chance of this, stated with the estimate: 30%); middle value at least 1.2-fold (0.09 log units) from the limit.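

In this assay, among the compounds shown here, compounds 3 and 4 form the first pair that isolates this aromatic carbon on the six-membered ring with 2 nitrogen, and replacing chloro with hydrogen gives an at least 3.2-fold higher number from compound 3 to compound 4 (0.50 log units; beyond the scatter). The chloro group is thus the one difference between a measurable number and a limit of the assay, and the true step may be larger than this floor. The other new pair exchanges 1H-indazol-6-yl for 1H-benzimidazol-6-yl and gives an at least 1.1-fold higher number from compound 1 to compound 4 (0.05 log units; that floor lies within the scatter), so it cannot show whether that exchange changes inhibition at all, and both steps remain floors rather than full sizes because the measurements stop at the top of the readable range: the limit of > 25000 nM in this assay, at which 2 of the 4 values shown sit.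

The compounds shown leave open whether a different atom or group on this aromatic carbon, such as fluoro, bromo, methyl or an amine, would behave like chloro or like hydrogen. They also leave open whether adding chloro at this position would produce a similar step on the core of compound 1, which carries 1H-indazol-6-yl.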